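Amide in Place of Benzyl: What to Expect

The source may hold more compounds than are shown below. What is called first, only, known or untested is meant among the compounds shown, and "the series" means these compounds.

Of the compounds shown here, three have been tested in a functional assay on CHO-K1 cells for agonist activity at somatostatin receptor type 2 (Homo sapiens), read by cAMP accumulation, with a stated time of 30 min; a lower number here means that less compound is needed, a higher number that more compound is needed for the effect. Compound 1 `Cc1cc(C)cc(-c2cncc(-c3nc4cc(C(F)(F)F)ccc4[nH]3)c2N2CCC(N)CC2)c1` gives 0.014 nM and compound 2 `NC1CCN(c2c(-c3cc(F)cc(Cl)c3)cncc2-c2nc3cc(F)ccc3[nH]2)CC1` gives 0.081 nM, while compound 3 `Cc1cc(C)cc(CNc2cncc(-c3cc(C)cc(C)c3)c2N2CCC(N)CC2)c1` gives 0.8 nM, the highest of the three numbers and so the least potent, with both gaps beyond the usual scatter. Compound 4 `Cc1cc(C)cc(C(=O)Nc2cncc(-c3cc(C)cc(C)c3)c2N2CCC(N)CC2)c1` has not yet been measured. It differs from compound 3 in one place: (3,5-dimethylphenyl)carbonyl in place of 3,5-dimethylbenzyl on a nitrogen on an aromatic ring. Among the compounds with values here, no measured pair shows this exact change, so its effect is uncertain; the expectation in this assay is a small step, if any, leaning toward a higher number. The estimated change is a 1.9-fold higher number from compound 3 to compound 4 (0.27 log units; within the scatter). Compound 4 is therefore expected to give about 1.5 nM, with a likely range from 0.3 nM to 8 nM.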

Compound 4, half-maximal effective concentration: 0.04 nM
For compound 4 the middle estimate is 38-fold (1.57 log units) above the measured one; measured number outside the range, below it.
By their numbers in this assay, from the lowest: compound 1; then compound 4; then compound 2; then compound 3.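

In this assay, (3,5-dimethylphenyl)carbonyl in place of 3,5-dimethylbenzyl on this nitrogen gives a 20-fold lower number from compound 3 to compound 4 (1.30 log units; beyond the scatter) and so shows that this position is sensitive to the change: the two groups share the same dimethylphenyl ring, and the carbonyl is what enters. Within the data shown here, this is the first single-place comparison, which the earlier compounds could not provide. Nothing measured here accounts for the size of this step. Still open, going by these compounds, is how a sulfonamide, a urea or a longer chain on this nitrogen would compare, and whether the amide hydrogen matters.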